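The source may report more compounds than this note shows. Statements on the series, on what has been measured and on what is new or still open speak of the compounds shown alone.

Three related compounds built on a shared core have been tested in a functional assay on U-251 cells (Homo sapiens) for cytotoxicity; on this read-out lower numbers stand for stronger inhibition of growth and higher numbers for weaker inhibition of growth. Compound 1 `COc1ccc(C2=C(c3cc(OC)c(OC)c(OC)c3)CC3CCCN3C2=O)cc1O` reads > 100000 nM, which is a limit of the assay and not a number. Compound 2 `COc1ccc(C2=C(c3ccc(SC)cc3)CC3CCCN3C2=O)cc1OC(=O)C1CCCN1C(=O)OC(C)(C)C` gives 2000 nM. Compound 3 `CSc1ccc(C2=C(c3ccc(O)c(O)c3)C(=O)N3CCCC3C2)cc1` gives 30000 nM, the higher of the two real numbers, so it is the weaker of that pair, and the gap to compound 2 lies beyond the usual scatter.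

The next compound to consider is compound 4 `CSc1ccc(C2=C(c3ccc(F)cc3)C(=O)N3CCCC3C2)cc1`, which has 4-fluorophenyl in place of 3,4-dihydroxyphenyl on a double-bonded ring carbon of compound 3: 4-fluorophenyl in place of 3,4-dihydroxyphenyl on a double-bonded ring carbon. The rest of the molecule, including the 4-(methylsulfanyl)phenyl group, stays the same.

Among the measured compounds shown here, no pair of measured compounds differs in only one place, so there is no direct precedent for the size of this step. For the measured compounds named here, the only guide is the spread of the measured values, and compound 2 at 2000 nM shows that this family can reach well under the number of compound 3. A moderate move toward stronger growth inhibition therefore seems likely, though with low confidence, and a result within the scatter would be no surprise. The expected change is a 3.0-fold lower number from compound 3 to compound 4 (0.48 log units; beyond the scatter). For compound 4 the estimated value is 10000 nM, with an expected range from 2000 nM to 50000 nM.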

Compound 4, concentration for 50% growth inhibition: 90 nM
For compound 4 the middle estimate is 110-fold (2.05 log units) above the measured one; measured number below the stated range.
By their numbers in this assay, from the lowest: compound 4; then compound 2; then compound 3. At a limit, above all of these: compound 1.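

In this assay, putting 4-fluorophenyl in place of 3,4-dihydroxyphenyl on the double-bonded ring carbon gives a 330-fold lower number from compound 3 to compound 4 (2.52 log units; beyond the scatter), while the 4-(methylsulfanyl)phenyl group and the rest of the molecule stay the same. Among the compounds shown here, this is the first one-place change, and it shows that the group on this carbon can have a very large effect on growth inhibition. The group that leaves carries hydrogen-bond donors and acceptors and the group that enters carries none, but nothing measured here shows why the swap has such a large effect.

On these data alone, because this single step changes the ring's substituents all at once, it remains open whether the gain depends on fluorine or on the loss of the two hydroxyl groups, which plain phenyl, 4-chlorophenyl, 4-hydroxyphenyl or 4-methoxyphenyl at this carbon would help to separate. As far as these compounds go, it is also open whether the same swap would have a similar effect with a group such as 4-methoxyphenyl in place of the 4-(methylsulfanyl)phenyl group.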